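A few compounds are considered here, and "the series" means these few. Any claim that something is new, unique, unknown or untested is made for them only; others in the source may bear on it.

Compound 1 `CC(C)N(c1cc(C#CC(C)(C)C)sc1C(=O)O)C(=O)[C@H]1CC[C@H](C)CC1` was examined in an ADME assay on MT4 cells (Homo sapiens) for cytotoxicity, with a stated time of 5 days; on this read-out higher numbers stand for lower toxicity in this test and lower numbers for higher toxicity in this test. In this assay compound 1 gives only a limit of > 20000 nM, not a number. Compound 2 `CC(C)N(C(=O)C1CCC(F)(F)CC1)c1cc(C#CC(C)(C)C)sc1C(=O)O` likewise reaches a limit of > 20000 nM. Compound 3 `CC(C)N(C(=O)[C@H]1[C@@H]2CCCC[C@@H]21)c1cc(C#CC(C)(C)C)sc1C(=O)O` also stops at a limit of > 20000 nM. All three values sit at the limit of > 20000 nM in this assay, at which 3 of the 3 values shown sit, so the steps a step that the two limits leave unreadable from compound 1 to compound 2 and a step that the two limits leave unreadable from compound 1 to compound 3 cannot be sized. Compound 4 `CC(C)(C)C#Cc1cc(N(C(=O)[C@H]2CC[C@H](C)CC2)[C@H]2CC[C@H](Oc3nccs3)CC2)c(C(=O)O)s1` differs from compound 1 in one place: 4-((1,3-thiazol-2-yl)oxy)cyclohexyl in place of isopropyl on an amide-type nitrogen. Among the measured compounds shown here, no measured step touches the amide-type nitrogen, so none speaks directly to this change; the measured steps only show that three variations of the group on the carbonyl carbon all ended at the same limit. Compound 4 is therefore expected to give 30000 nM, between 10000 nM and 100000 nM, which would mean an expected step that the limit leaves unreadable from compound 1 to compound 4.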

Compound 4, half-maximal cytotoxic concentration: > 20000 nM
Compound 4: no number, only a limit (the forecaster's own chance of this, stated with the estimate: 80%); the middle value does not contradict the limit.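

Among the compounds shown here, compound 1 and compound 4 both stop at a limit rather than a number, so no step between them can be read: the limit of > 20000 nM in this assay, at which 4 of the 4 values shown sit. The compounds shown leave open whether any of these group changes shifts the read-out in this assay at all.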